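A few compounds are considered here, and "the series" means these few. Any claim that something is new, unique, unknown or untested is made for them only; others in the source may bear on it.

Working notes on the series. Compound 3 `CCCn1c(=O)[nH]c2nc(-c3ccc(S(=O)(=O)N4CCN(c5ccc(Cl)cc5F)CC4)cc3)[nH]c2c1=O` carries a 4-chloro-2-fluorophenyl on an amine nitrogen in a ring of the shared core. In an assay on CHO cells for displacement of a labelled ligand from adenosine receptor A3 (Homo sapiens), read by scintillation counting, with a stated time of 45 min, in the presence of a further agent that is not named here (a lower number here means a stronger inhibitor, a higher number a weaker inhibitor), compound 3 gives > 1000 nM, which is a limit of the assay and not a number. Compound 1 `CCCn1c(=O)[nH]c2nc(-c3ccc(S(=O)(=O)N4CCN(c5cccc(F)c5)CC4)cc3)[nH]c2c1=O` bears a 3-fluorophenyl on that amine nitrogen. In this assay compound 1 gives > 1000 nM, again a limit. Compound 2 `CCCn1c(=O)[nH]c2nc(-c3ccc(S(=O)(=O)N4CCN(c5ccc(I)cc5)CC4)cc3)[nH]c2c1=O` bears a 4-iodophenyl on that amine nitrogen. In this assay compound 2 gives > 1000 nM, also a limit. The steps a step that the two limits leave unreadable from compound 1 to compound 2, a step that the two limits leave unreadable from compound 1 to compound 3 and a step that the two limits leave unreadable from compound 2 to compound 3 accordingly have no readable size; all that is known is the limit of > 1000 nM in this assay, at which 3 of the 3 values shown sit.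

Compound 4 `CCCn1c(=O)[nH]c2nc(-c3ccc(S(=O)(=O)N4CCN(c5cccc(Cl)c5)CC4)cc3)[nH]c2c1=O` is the next member. The change from compound 3 is 3-chlorophenyl in place of 4-chloro-2-fluorophenyl on an amine nitrogen in a ring. Within the data shown here, no measured step gives a readable size, so no direction can be drawn for this change; among compounds 1, 2 and 3 each variation of the phenyl group on the amine nitrogen in the ring has left the value at the limit. Compound 4 is therefore expected to give 3000 nM, within 800 nM to 20000 nM, most probably reported only as a limit once more. The expected step is a step that the limit leaves unreadable from compound 3 to compound 4.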

Compound 4, inhibition constant: 53.5 nM
Beside the measured number, compound 4's estimate is 56-fold (1.75 log units) above it; measured number outside the range, below it.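

In this assay, the phenyl group on the amine nitrogen in the ring proves able to move the number: the change to 3-chlorophenyl gives an at least 18-fold lower number from compound 3 to compound 4 (1.27 log units; beyond the scatter) and an at least 18-fold lower number from compound 2 to compound 4 (1.27 log units; beyond the scatter). Among these compounds, the closest pair is the one with a single exchange, chloro in place of fluoro on an aromatic carbon, which gives an at least 18-fold lower number from compound 1 to compound 4 (1.27 log units; beyond the scatter), so this one atom on the phenyl group is enough to bring the series into a readable range. Compound 4 is the only compound shown that stands clear of the limit: the limit of > 1000 nM in this assay, at which 3 of the 4 values shown sit.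

On these data alone, the true sizes of these steps stay open, as each has a limit at one end. Also open, as far as these compounds go, is whether 3-bromophenyl or 3-methoxyphenyl would keep a readable value like that of compound 4.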